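Swapping ethyl for pyridin-2-yl on the ring nitrogen

A few compounds are considered here, and "the series" means these few. Any claim that something is new, unique, unknown or untested is made for them only; others in the source may bear on it.

Compound 1 `COc1ccc(C[C@@H](O)/C=C/C=C/C(=O)N2CCN(c3ccccc3)CC2)cc1OC` gives 9430 nM
Compound 2 `CCN1CCN(C(=O)/C=C/C=C/[C@H](O)Cc2ccc(OC)c(OC)c2)CC1` gives 10800 nM

In a functional assay on IMR-32 cells (Homo sapiens) for antiproliferative activity, read by sulforhodamine B assay, with a stated time of 48 h (on this read-out higher numbers stand for weaker inhibition and lower numbers for stronger inhibition), compound 2 gives 10800 nM and sits level with compound 1 within the scatter. Compound 3 `COc1ccc(C[C@@H](O)/C=C/C=C/C(=O)N2CCN(c3ccccn3)CC2)cc1OC`, not yet measured, has pyridin-2-yl in place of ethyl on an amine nitrogen in a ring, a change counted as pyridin-2-yl in place of ethyl on an amine nitrogen in a ring in full. Within the data shown here, the one measured step at this place, a 1.1-fold higher number from compound 1 to compound 2 (0.06 log units; within the scatter) for ethyl in place of phenyl, stayed within the scatter. So this assay is expected to show no step beyond the scatter, with an estimated 1.1-fold lower number from compound 2 to compound 3 (0.04 log units; within the scatter) overall. Compound 3 is expected at 9800 nM with a likely range from 4800 nM to 20000 nM in this estimate.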

Compound 3, half-maximal inhibitory concentration: 11100 nM
Compound 3: middle estimate off by 1.1-fold (0.05 log units), on the low side; the range from low to high includes it.
By their numbers in this assay, from the lowest: compounds 1, 2 and 3 (each within the scatter of the next).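

In this assay, the step of a 1.0-fold higher number from compound 2 to compound 3 (0.01 log units; within the scatter) and the step of a 1.2-fold higher number from compound 1 to compound 3 (0.07 log units; within the scatter) both lie within the scatter. On this amine nitrogen in a ring, pyridin-2-yl therefore cannot be told apart from ethyl or phenyl, even though, unlike ethyl, it brings an aromatic ring and a hydrogen-bond acceptor. No evidence is available to explain this level result. Still open, from the compounds shown here alone, is whether a different kind of group here, such as a benzyl group or a longer chain ending in a carboxylic acid, would give a step beyond the scatter.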